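Widening the Acid-Bearing Ring: Solubility Expectation

The source may report more compounds than this note shows. Statements on the series, on what has been measured and on what is new or still open speak of the compounds shown alone.

Compound 1 `CCNC(=O)Nc1nc2cc(-c3cnc(N4CCC(CC)(C(=O)O)CC4)nc3)cc(-c3ccccn3)c2s1` was measured in a physicochemical assay for solubility, read by turbidimetry, in phosphate buffer, with a stated time of 24 h, at pH 7.4 (a lower number here means a less soluble compound, a higher number a more soluble compound), where compound 1 reaches a limit of the assay, > 800 ug/mL. Compound 2 `CCNC(=O)Nc1nc2cc(-c3cnc(N4CCC(C(=O)O)(S(C)(=O)=O)CC4)nc3)cc(-c3ccccn3)c2s1` likewise sits at a limit, giving > 800 ug/mL in this assay. The step that the two limits leave unreadable from compound 1 to compound 2 therefore has no readable size, as the limit of > 800 ug/mL in this assay, at which 2 of the 2 values shown sit, shows. Compound 3 `CCNC(=O)Nc1nc2cc(-c3cnc(N4CCCC(C)(C(=O)O)CC4)nc3)cc(-c3ccccn3)c2s1` differs from compound 1 by 4-carboxy-4-methylazepan-1-yl in place of 4-carboxy-4-ethylpiperidin-1-yl on an aromatic carbon. Going by the values given here, no measured step bears directly on this change. Compound 3 is expected to give 800 ug/mL in this assay. For compound 3 the estimated range runs from 500 ug/mL to 1200 ug/mL. The expected step of a number no higher from compound 1 to compound 3 (the limit leaves the size open) lies within the usual scatter.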

Compound 3, solubility: > 800 ug/mL
Compound 3: no number, only a limit (the forecaster's own chance of this, stated with the estimate: 80%); the middle value sits exactly at the limit.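

No size can be read for the change from compound 1 to compound 3, because both compounds, like compound 2, give a limit rather than a number: the limit of > 800 ug/mL in this assay, at which 3 of the 3 values shown sit.

Going by these compounds, whether 4-carboxy-4-methylazepan-1-yl and 4-carboxy-4-ethylpiperidin-1-yl differ in solubility remains open.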